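The source may hold more compounds than are shown below. What is called first, only, known or untested is meant among the compounds shown, and "the series" means these compounds.

Compound 1 `O=C(/C=C\Nc1ccc(Cl)cc1)c1cn(-c2ccccc2)nc1-c1ccc(Cl)cc1` and compound 3 `COc1ccc(-c2nn(-c3ccccc3)cc2C(=O)/C=C\Nc2ccc(Cl)cc2)cc1` share a core and differ in one place: methoxy in place of chloro on an aromatic carbon. In a functional assay on HT-29 cells (Homo sapiens) for antiproliferative activity, read by MTT assay, with a stated time of 48 h (a lower number here means a stronger inhibitor, a higher number a weaker inhibitor), compound 1 gives 4650 nM. In this assay compound 3 gives 4760 nM, and the step of a 1.0-fold higher number from compound 1 to compound 3 (0.01 log units; within the scatter). Compound 2 `O=C(/C=C\Nc1ccc(C(F)(F)F)cc1)c1cn(-c2ccccc2)nc1-c1ccc(Cl)cc1` is compound 1 with a single change: trifluoromethyl in place of chloro on an aromatic carbon. For compound 2 the result is a limit of the assay, > 50000 nM. The step of an at least 10-fold higher number from compound 1 to compound 2 (1.03 log units; beyond the scatter); its stated size rests on (the limit of > 50000 nM in this assay, at which 1 of the 3 values shown sits). Compound 4 `COc1ccc(-c2nn(-c3ccccc3)cc2C(=O)/C=C\Nc2ccc(C(F)(F)F)cc2)cc1`, which has not yet been measured, is compound 3 with the same change made on the same kind of position: trifluoromethyl in place of chloro on an aromatic carbon. Since the earlier instance of this change produced the step of an at least 10-fold higher number from compound 1 to compound 2 (1.03 log units; beyond the scatter), a step of about the same size is expected for compound 4: an 11-fold higher number from compound 3 to compound 4 (1.02 log units; beyond the scatter). For compound 4 the expected value in this assay is estimated at 50000 nM, with a likely range from 20000 nM to 150000 nM, and a good chance that the assay again reports only a limit.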

Compound 4, half-maximal inhibitory concentration: 9870 nM
For compound 4 the middle estimate is 5.1-fold (0.70 log units) above the measured one; the whole stated range lies above it.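

Putting trifluoromethyl in place of chloro gives a 2.1-fold higher number from compound 3 to compound 4 (0.32 log units; beyond the scatter) in this assay, so the number rises on both cores, but the step does not carry over at the same size: the same change on two cores in this assay, an at least 10-fold higher number (1.03 log units; beyond the scatter) from compound 1 to compound 2 and a 2.1-fold higher number (0.32 log units; beyond the scatter) from compound 3 to compound 4, at least 5.1-fold (0.71 log units) apart, beyond the scatter of two such steps. Read the other way, methoxy in place of chloro gives an at least 5.0-fold lower number from compound 2 to compound 4 (0.70 log units; beyond the scatter) in the trifluoromethyl pair, whereas it gives a 1.0-fold higher number from compound 1 to compound 3 (0.01 log units; within the scatter) in the chloro pair, so the two changes do not simply add up: the same change on two cores in this assay, a 1.0-fold higher number (0.01 log units; within the scatter) from compound 1 to compound 3 and an at least 5.0-fold lower number (0.70 log units; beyond the scatter) from compound 2 to compound 4, at least 5.1-fold (0.71 log units) apart, beyond the scatter of two such steps. Compound 2 is known only as a limit of the assay, so the true size of its steps stays open, and two pairs neither give a rule for other cores nor explain why these cores differ: the limit of > 50000 nM in this assay, at which 1 of the 4 values shown sits.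

From the compounds shown here alone, whether the same dependence on the core holds for an amine or a carboxylic acid in place of the trifluoromethyl remains open. So does the behaviour of a core with a plain hydrogen in place of the methoxy or chloro.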